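Working notes: from compound 3 to compound 4

The source may report more compounds than this note shows. Statements on the series, on what has been measured and on what is new or still open speak of the compounds shown alone.

Measured in a physicochemical assay for solubility, measured as kinetic solubility, at pH 2; a lower number here means a less soluble compound, a higher number a more soluble compound:
- compound 1 `CC(C)C(Nc1nnc[nH]1)c1ccc(-c2ccc3cccc(F)c3c2)[nH]c1=O`: 39000 nM
- compound 2 `CC(C)C(c1ccc(-c2ccc3cccc(F)c3c2)[nH]c1=O)N1CCN/C1=N\C#N`: 32500 nM
- compound 3 `CC(C)C(Cc1nnn[nH]1)c1ccc(-c2ccc3cccc(F)c3c2)[nH]c1=O`: 28000 nM

Compound 3 cannot be told apart from the other two compounds, as a 1.4-fold lower number from compound 1 to compound 3 (0.14 log units; within the scatter) and a 1.2-fold lower number from compound 2 to compound 3 (0.06 log units; within the scatter) both stay within the scatter. Compound 4 `CC(C)NC(=O)CC(c1ccc(-c2ccc3cccc(F)c3c2)[nH]c1=O)C(C)C` has not been measured. It differs from compound 3 by one exchange: isopropylcarbamoyl in place of 1H-tetrazol-5-yl on a saturated chain carbon, two bonds along the chain from an aromatic carbon. The group sits on a saturated chain carbon, two bonds along the chain from an aromatic carbon. The three measured steps bear on this, the third being a 1.2-fold lower number from compound 1 to compound 2 (0.08 log units; within the scatter). Among the compounds with values here, all are small, but no measured compound carries isopropylcarbamoyl, so the guidance is limited. The expected step, a 1.4-fold lower number from compound 3 to compound 4 (0.15 log units; within the scatter), stays within the scatter. Compound 4 is estimated at 20000 nM, with an expected range of 6000 nM to 40000 nM.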

Compound 4, solubility: 24200 nM
Compound 4: middle estimate off by 1.2-fold (0.08 log units), on the low side; measured number inside the range.
By their numbers in this assay, from the lowest: compounds 4, 3, 2 and 1 (each within the scatter of the next).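

In this assay isopropylcarbamoyl in place of 1H-tetrazol-5-yl gives a 1.2-fold lower number from compound 3 to compound 4 (0.06 log units; within the scatter) and shows that a group with no ring at this place cannot be told apart from the ring-bearing groups. Likewise a 1.3-fold lower number from compound 2 to compound 4 (0.13 log units; within the scatter) and a 1.6-fold lower number from compound 1 to compound 4 (0.21 log units; within the scatter) both stay within the scatter, so the four compounds remain a single level in this read-out. No data here give a cause for this.

Still open, on these data alone, is whether an amine or a carboxylic acid on this saturated chain carbon would give a step beyond the scatter.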